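The source may hold more compounds than are shown below. What is called first, only, known or untested is meant among the compounds shown, and "the series" means these compounds.

Working notes on the series. Compound 2 `CC(c1ccc(-c2ccccc2)c(F)c1)c1nnc2n1N=C(c1ccc(Cl)cc1Cl)CS2` is one of two members with a number in a functional assay on FOCUS cells (Homo sapiens) for inhibition, read by sulforhodamine B assay, with a stated time of 72 h; on this read-out higher numbers stand for weaker inhibition and lower numbers for stronger inhibition: compound 2 gives 5400 nM, the lowest of the two numbers. Compound 1 `Cc1ccc(C2=Nn3c(nnc3C(C)c3ccc(CC(C)C)cc3)SC2)cc1` gives 6800 nM in this assay, a gap to compound 2 that lies within the scatter, so no order between the two is claimed. Compound 3 `CC(c1ccc(-c2ccccc2)c(F)c1)c1n[nH]c(=S)n1N` is reported in this assay as "not active" (no number reported), without a number. Compound 4 `COc1ccc(C2=Nn3c(nnc3C(C)c3ccc(-c4ccccc4)c(F)c3)SC2)cc1` differs from compound 2 in one place: 4-methoxyphenyl in place of 2,4-dichlorophenyl on a carbon with a double bond to nitrogen. Within the data shown here, no measured pair shows this change, so the size of the step from compound 2 to compound 4 rests on no direct precedent; no step beyond the scatter is expected in either direction, and the expected step is a 1.2-fold higher number from compound 2 to compound 4 (0.08 log units; within the scatter). Compound 4 is therefore estimated at 6500 nM in this assay, within a range from 2500 nM to 20000 nM.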

Compound 4, half-maximal inhibitory concentration: 4400 nM
Compound 4: the middle estimate sits 1.5-fold (0.17 log units) above what was measured, and the stated range covers the measured number.
By their numbers in this assay, from the lowest: compounds 4, 2 and 1 (each within the scatter of the next).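

In this assay, the change at this position, on a carbon with a double bond to nitrogen, now has a direct reading: a 1.2-fold lower number from compound 2 to compound 4 (0.09 log units; within the scatter) stays within the scatter. Here 4-methoxyphenyl, with its hydrogen-bond acceptor, and 2,4-dichlorophenyl, with none, give numbers that cannot be told apart. Nothing available explains this result.

The compounds with a number carry only substituted phenyl groups on this carbon. Going by these compounds, what an amine or a carboxylic acid would do at this position remains open, as does whether any group here moves the number beyond the scatter.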